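Swapping the Benzyl Arm for a Tetrazolylmethyl Arm

The compounds below may be only part of what the source reports. "The series", "measured", "known", "first", "only" and "open" are said of these compounds alone.

Three measured compounds share one core and differ only in the group on a saturated chain carbon bound to a saturated ring carbon. Compound 1 `CCC(C)n1ncn(-c2ccc(N3CCN(c4ccc(OC[C@@H]5CO[C@@](Cc6ccccc6)(c6ccc(Cl)cc6Cl)O5)cc4)CC3)cc2)c1=O` carries a phenyl there, and in a functional assay on HUVEC cells (Homo sapiens), read by scintillation counting and thymidine incorporation, with a stated time of 24 h (a lower number here means a stronger inhibitor, a higher number a weaker inhibitor), compound 1 gives 513 nM. That is the highest of the three numbers, though the gap to compound 3 lies within the scatter. Compound 2 `CCc1nccn1C[C@@]1(c2ccc(Cl)cc2Cl)OC[C@@H](COc2ccc(N3CCN(c4ccc(-n5cnn(C(C)CC)c5=O)cc4)CC3)cc2)O1` gives 224 nM, and compound 3 `CCC(C)n1ncn(-c2ccc(N3CCN(c4ccc(OC[C@@H]5CO[C@@](Cn6cc(C)nc6C)(c6ccc(Cl)cc6Cl)O5)cc4)CC3)cc2)c1=O` gives 492 nM.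

Compound 4 `CCC(C)n1ncn(-c2ccc(N3CCN(c4ccc(OC[C@@H]5CO[C@@](Cn6ncnn6)(c6ccc(Cl)cc6Cl)O5)cc4)CC3)cc2)c1=O` differs from compound 1 in the same place: 2H-tetrazol-2-yl in place of phenyl on a saturated chain carbon bound to a saturated ring carbon. The two measured steps that bear on this both replaced phenyl with a small nitrogen-containing aromatic ring. One was a 2.3-fold lower number from compound 1 to compound 2 (0.36 log units; beyond the scatter), the other 1.0-fold lower number from compound 1 to compound 3 (0.02 log units; within the scatter). So a change of this kind has given at most a modest gain, and once no change beyond the scatter.

Compound 4 is therefore expected to give about 400 nM, with a plausible range from 150 nM to 1100 nM. The expected step is a 1.3-fold lower number from compound 1 to compound 4 (0.11 log units; within the scatter), small and possibly within the scatter.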

Compound 4, half-maximal inhibitory concentration: 124 nM
The estimate for compound 4 lay 3.2-fold (0.51 log units) above the measured number; the measured number lies below the stated range.
By their numbers in this assay, from the lowest: compounds 4 and 2 (each within the scatter of the next); then compounds 3 and 1 (each within the scatter of the next).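

This position is not limited to slight changes: 2H-tetrazol-2-yl in place of phenyl gives, in this assay, a 4.1-fold lower number from compound 1 to compound 4 (0.62 log units; beyond the scatter), and in place of 2,4-dimethyl-1H-imidazol-1-yl it gives a 4.0-fold lower number from compound 3 to compound 4 (0.60 log units; beyond the scatter). Against 2-ethyl-1H-imidazol-1-yl it gives a 1.8-fold lower number from compound 2 to compound 4 (0.26 log units; within the scatter), so no order can be drawn between those two groups, and swapping phenyl for a nitrogen-containing aromatic ring does not by itself settle the number, as compound 3 goes against any such rule. No measurement shown explains why these rings differ.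

On these data alone, it remains open whether the tetrazole ring itself matters or whether other rings would serve as well. An unsubstituted imidazole or a triazole on the same chain carbon would test this, and an open-chain amine would show whether an aromatic ring is needed there at all.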